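The source may report more compounds than this note shows. Statements on the series, on what has been measured and on what is new or still open speak of the compounds shown alone.

Of the compounds shown here, three sharing one core have been measured in a functional assay on A549 cells (Homo sapiens) for inhibition, read by MTT assay, with a stated time of 72 h; on this read-out lower numbers stand for stronger inhibition and higher numbers for weaker inhibition. Compound 1 `CC1=NN(c2ccccc2)C(=O)[C@@]12C(=O)C=CC[C@@H]2c1ccccc1[N+](=O)[O-]` gives 66400 nM, compound 2 `COc1ccccc1[C@H]1CC=CC(=O)[C@@]12C(=O)N(c1ccccc1)N=C2C` gives 18700 nM, and compound 3 `CC1=NN(c2ccccc2)C(=O)[C@]12C(=O)C=CC[C@H]2c1ccccc1` gives 8290 nM, the lowest number of the three and so the strongest inhibition among them. Compound 4 `CC1=NN(c2ccccc2)C(=O)[C@@]12C(=O)C=CC[C@@H]2c1ccccc1` is built from the same atoms and bonds as compound 3, and only its configuration differs: the two compounds have the same atoms and bonds and differ only in configuration as drawn: 2 of 2 stereo elements differ (all stereocentres are inverted: mirror images); a stereocentre at a saturated ring carbon is drawn S in compound 3 and R in compound 4; a stereocentre at a saturated ring carbon is drawn S in compound 3 and R in compound 4. For the measured compounds named here, the one measured step, a 3.6-fold lower number from compound 1 to compound 2 (0.55 log units; beyond the scatter), is a modest change, but it swaps one group for another and does not touch configuration. Going by the values given here, no pair of mirror images has been measured, so the data give no direct size for this kind of change. With compound 3 at the low end of the range at 8290 nM, any shift seems likelier to go towards a higher number, though no step beyond the scatter is expected. The expected result is a 1.4-fold higher number from compound 3 to compound 4 (0.16 log units; within the scatter). The estimate for compound 4 is 12000 nM, with an expected range from 4500 nM to 35000 nM.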

Compound 4, half-maximal inhibitory concentration: 7770 nM
The estimate for compound 4 lay 1.5-fold (0.19 log units) above the measured number; the measured number falls inside the stated range.
By their numbers in this assay, from the lowest: compounds 4 and 3 (each within the scatter of the next); then compound 2; then compound 1.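

In this assay, the mirror-image pair gives a 1.1-fold lower number from compound 3 to compound 4 (0.03 log units; within the scatter), so inverting both stereocentres produces no difference that can be told from the scatter on this read-out. For the compounds shown here, this comparison isolates configuration alone: the fact that compounds 3 and 4 differ only in the configuration as drawn With the new compound, hydrogen in place of methoxy on an aromatic carbon gives a 2.4-fold lower number from compound 2 to compound 4 (0.38 log units; beyond the scatter), and hydrogen in place of nitro gives an 8.5-fold lower number from compound 1 to compound 4 (0.93 log units; beyond the scatter), so both of these groups go with weaker inhibition than hydrogen at that place when the configuration is the one drawn for compound 4.

From the compounds shown here alone, it remains open how an amine or a carboxylic acid on that aromatic carbon would compare with hydrogen. Also open, going by these compounds, is whether inverting just one of the two stereocentres would move the number, and whether inverting both would do so with methoxy or nitro present.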